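Sulfonamide for pyrazole on a fused bicyclic imidazoline scaffold

The compounds below may be only part of what the source reports. "The series", "measured", "known", "first", "only" and "open" are said of these compounds alone.

Compound 1 `c1ccc(-c2cccc3c2CCC3c2ncc[nH]2)nc1`: in a functional assay on CHO cells for agonist activity at Alpha-1B adrenergic receptor (Homo sapiens), read by FLIPR and calcium flux (a lower number here means that less compound is needed, a higher number that more compound is needed for the effect), compound 1 gives > 10000 nM.
Compound 2 `Cn1nccc1-c1cccc2c1CCC2c1ncc[nH]1`: compound 2 gives > 10000 nM.
Compound 3 `CS(=O)(=O)Nc1c(Cl)ccc2c1CCCC2c1ncc[nH]1`: compound 3 gives > 10000 nM.

Each of these three values is a limit of this assay, not a number, so compound 2 stands only at that limit. For the measured compounds named here, the one measured step, a step that the two limits leave unreadable from compound 1 to compound 2, is unreadable for the same reason. Compound 4 `CCS(=O)(=O)Nc1cccc2c1CCC2c1ncc[nH]1` differs from compound 2 by (ethylsulfonyl)amino in place of 1-methyl-1H-pyrazol-5-yl on an aromatic carbon. Going by the values given here, no measured step bears on this change; the only guidance is the limit of > 10000 nM in this assay, at which 3 of the 3 values shown sit, and compound 3, which also carries a sulfonyl-amino group, sits at that limit too. Compound 4 is therefore expected at or near the limit, with a step that the limit leaves unreadable from compound 2 to compound 4, and its estimated value is 15000 nM (3000 nM to 60000 nM).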

Compound 4, half-maximal effective concentration: > 10000 nM
Compound 4 was reported as a limit; the forecaster's own chance of this, stated with the estimate: 70%; the middle value is on the limit's open side.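

In this assay, for the compounds shown here, compound 4 gives > 10000 nM, a limit and not a number, so no step from compound 1 or compound 2 to compound 4 can be read. The compounds shown leave open whether any change to the shared core gives a number in this assay: the limit of > 10000 nM in this assay, at which 4 of the 4 values shown sit.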